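Replacing 3-methoxyphenyl with 4-bromophenyl on the shared core

The source may report more compounds than this note shows. Statements on the series, on what has been measured and on what is new or still open speak of the compounds shown alone.

In a functional assay on Huh-7 cells (Homo sapiens) for cytotoxicity, with a stated time of 48 h (on this read-out higher numbers stand for weaker inhibition and lower numbers for stronger inhibition), compound 1 (`COc1cccc(/C=C/C(=O)c2c(OC)cc(OC)cc2OC)c1`) gives 8900 nM and stands within the scatter of compound 2 (`COc1cc(OC)c(C(=O)/C=C/c2ccc(Cl)cc2)c(OC)c1`) at 12700 nM and of compound 3 (`COc1cc(OC)c(C(=O)/C=C/c2ccc(F)cc2)c(OC)c1`) at 14600 nM on the same read-out. Compound 4 (`COc1cc(OC)c(C(=O)/C=C/c2ccc(Br)cc2)c(OC)c1`), not yet measured, carries 4-bromophenyl in place of 3-methoxyphenyl (4-bromophenyl in place of 3-methoxyphenyl on a double-bonded chain carbon bound to a double-bonded chain carbon) on a double-bonded chain carbon. The closest measured changes are 4-chlorophenyl (a 1.4-fold higher number from compound 1 to compound 2 (0.15 log units; within the scatter)) and 4-fluorophenyl (a 1.6-fold higher number from compound 1 to compound 3 (0.21 log units; within the scatter)) in that same place, while fluoro in place of chloro gives (a 1.1-fold higher number from compound 2 to compound 3 (0.06 log units; within the scatter)), all within the scatter. The expected step (a 1.4-fold higher number from compound 1 to compound 4 (0.15 log units; within the scatter)) in this assay therefore stays within the scatter, with no firm direction. Compound 4 is estimated at 12500 nM with an expected range from 7000 nM to 21000 nM for this read-out.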

Compound 4, half-maximal inhibitory concentration: 13900 nM
Compound 4: the middle estimate sits 1.1-fold (0.05 log units) below what was measured, and the stated range covers the measured number.
By their numbers in this assay, from the lowest: compounds 1, 2, 4 and 3 (each within the scatter of the next).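

In this assay, the step to 4-bromophenyl, a 1.6-fold higher number from compound 1 to compound 4 (0.19 log units; within the scatter), extends the set of groups tolerated at this place on a double-bonded chain carbon without moving the number beyond the scatter. Bromo in place of chloro gives a 1.1-fold higher number from compound 2 to compound 4 (0.04 log units; within the scatter), and bromo in place of fluoro gives a 1.1-fold lower number from compound 3 to compound 4 (0.02 log units; within the scatter), so the three halogen-bearing compounds cannot be told apart in this series. Nothing available bears on the reason for this flat result. From the compounds shown here alone, whether an amine or a carboxylic acid on the phenyl ring at this place would give a step beyond the scatter remains open.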